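The source may hold more compounds than are shown below. What is called first, only, known or untested is meant among the compounds shown, and "the series" means these compounds.

Measured so far, in a functional assay on NCI-H292 cells (Homo sapiens) for antiproliferative activity; on this read-out higher numbers stand for weaker inhibition and lower numbers for stronger inhibition:
compound 1 `COc1ccc(N2C(=O)N/C(=C\c3ccc(O)cc3)C2=O)cc1` — > 200000 nM, a limit of this assay
compound 2 `O=C1N/C(=C\c2ccc(O)cc2)C(=O)N1c1ccc(Br)cc1` — 69900 nM

Going by the values given here, compound 2 thus carries the only number in this assay; the other value is a limit. Compound 3 `O=C(Nc1ccc(Cl)cc1)c1ccc(N2C(=O)N/C(=C\c3ccc(O)cc3)C2=O)cc1` differs from compound 2 by (4-chlorophenyl)carbamoyl in place of bromo on an aromatic carbon. Among the compounds with values here, the one measured step at that same aromatic carbon is an at least 2.8-fold lower number from compound 1 to compound 2 (0.45 log units; beyond the scatter), which is at least modest. On that basis a further modest lowering is expected in this assay, with wide uncertainty, as the entering group is far larger than either earlier substituent. Compound 3 is estimated at 30000 nM, within 8000 nM to 120000 nM. This corresponds to an expected step of a 2.3-fold lower number from compound 2 to compound 3 (0.37 log units; beyond the scatter).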

Compound 3, half-maximal inhibitory concentration: > 200000 nM
Compound 3: no number, only a limit; the forecaster's own chance of this, stated with the estimate: 10%; at least 6.6-fold (0.82 log units) between middle value and limit.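

In this assay, bromo at this aromatic carbon cannot be replaced by just any group: (4-chlorophenyl)carbamoyl gives an at least 2.8-fold higher number from compound 2 to compound 3 (0.45 log units; beyond the scatter), so the lowering seen with bromo does not carry over to this much larger substituent. The step linking compound 1 and compound 3 cannot be read, since both values are limits. Compound 2 therefore remains the only compound with a number, and the rest of the series sits at a limit: the limit of > 200000 nM in this assay, at which 2 of the 3 values shown sit.

On these data alone, it remains open whether the chlorophenyl ring or the carbamoyl unit accounts for the step. Also open, as far as these compounds go, is how chloro, an amine or a carboxylic acid would read on the same aromatic carbon.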